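The compounds below may be only part of what the source reports. "The series", "measured", "known", "first", "only" and "open" are said of these compounds alone.

In an assay on isolated protein with Bile acid receptor (Homo sapiens) as the target (on this read-out lower numbers stand for an effect already at smaller amounts and higher numbers for an effect only at larger amounts of compound), compound 2 `COC(=O)/C=C/c1cccc(N(Cc2ccc(/C=C/C(=O)OC(C)(C)C)cc2OC)C(=O)C2CCCCC2)c1` reaches only a limit of the assay and gives > 1000 nM. Compound 1 `COC(=O)/C=C/c1cccc(N(Cc2cccc(OC)c2)C(=O)C2CCCCC2)c1` likewise reaches only a limit in this assay, giving > 1000 nM. Taken together, both results belong to the limit of > 1000 nM in this assay, at which 2 of the 2 values shown sit, so neither compound shows an effect within the range the measurement covers. Compound 3 `COC(=O)/C=C/c1cccc(N(Cc2ccc(/C=C/C(=O)OC(C)(C)C)cc2OS(C)(=O)=O)C(=O)C2CCCCC2)c1` is the compound still to be measured. It differs from compound 2 in one place: methylsulfonyl in place of methyl on an oxygen on an aromatic ring, so that the methoxy becomes a (methylsulfonyl)oxy group. Among the compounds with values here, no step between two measured compounds is available to suggest how large such a change might be, and the two measured values give no direction either. The step that the limit leaves unreadable from compound 2 to compound 3 is therefore expected to stay within the usual scatter. Compound 3 is estimated at 3000 nM, in a range from 800 nM to 20000 nM, and most likely again reported only as a limit.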

Compound 3, half-maximal effective concentration: > 1000 nM
Compound 3: no number, only a limit; the forecaster's own chance of this, stated with the estimate: 85%; the middle value lies beyond the limit too.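

No step can be read from compound 2 to compound 3, because both results are limits rather than numbers: the limit of > 1000 nM in this assay, at which 3 of the 3 values shown sit. The compounds shown leave open how strongly each acts in this assay and whether replacing methoxy with (methylsulfonyl)oxy changes that at all.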